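A few compounds are considered here, and "the series" means these few. Any claim that something is new, unique, unknown or untested is made for them only; others in the source may bear on it.

Measured so far in a functional assay for inhibition of sodium/hydrogen exchanger (Oryctolagus cuniculus); on this read-out higher numbers stand for weaker inhibition and lower numbers for stronger inhibition:
compound 1 `Cc1cc(C2CCCCC2)c(S(C)(=O)=O)cc1C(=O)N=C(N)N` gives 22 nM
compound 2 `CS(=O)(=O)c1cc(C(=O)N=C(N)N)ccc1-n1cccn1` gives 160 nM
compound 3 `CS(=O)(=O)c1cc(C(=O)N=C(N)N)ccc1C1CCCCC1` gives 340 nM

Compound 3 gives the highest number of the three in this assay; compound 2 stands nearest to it and compound 1 furthest. The two steps recorded into compound 3 are a 15-fold higher number from compound 1 to compound 3 (1.19 log units; beyond the scatter) and a 2.1-fold higher number from compound 2 to compound 3 (0.33 log units; beyond the scatter).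

Compound 4 `CS(=O)(=O)c1cc(C(=O)N=C(N)N)ccc1-n1ccc(=O)cc1` has not been measured. It differs from compound 3 by a group of 7 heavy atoms (5 carbon, 1 nitrogen, 1 oxygen; one six-membered aromatic ring with 1 hetero atom) in place of a group of 6 heavy atoms (6 carbon; one six-membered non-aromatic ring of carbon only), on an aromatic carbon. The step from compound 1 to compound 3 concerns the methyl and does not touch the group swapped here. The step from compound 2 to compound 3 does bear on it: there a ring containing hetero atoms stood at the same site, ortho to the methylsulfonyl group, and the change to cyclohexyl gave a modest rise. Going by the values given here, no measured compound carries the group entering in compound 4, so the direction is taken from compound 2 alone and with little confidence. On that basis compound 4 is expected to give a modestly lower number than compound 3 in this assay, an estimated step of a 1.4-fold lower number from compound 3 to compound 4 (0.13 log units; within the scatter). Compound 4 is thus estimated at 250 nM, with a range from 80 nM to 900 nM.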

Compound 4, half-maximal inhibitory concentration: 710 nM
The estimate for compound 4 lay 2.8-fold (0.45 log units) below the measured number, within the range that was stated.
By their numbers in this assay, from the lowest: compound 1; then compound 2; then compound 3; then compound 4.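

In this assay, replacing cyclohexyl on the aromatic carbon ortho to a methylsulfonyl group with the new six-membered aromatic ring, which has 1 hetero atom and 1 double bond outside it, raises the number (a 2.1-fold higher number from compound 3 to compound 4 (0.32 log units; beyond the scatter)). Compared with 1H-pyrazol-1-yl at the same site, the rise is larger (a 4.4-fold higher number from compound 2 to compound 4 (0.65 log units; beyond the scatter)), so among compound 2, compound 3 and compound 4 a hetero-atom ring does not in itself give a lower number than cyclohexyl: compound 2 falls below compound 3, while compound 4 rises above it. Nothing at hand accounts for this order of the three groups.

Still open, as far as these compounds go, is whether the methyl seen in the earlier step (a 15-fold higher number from compound 1 to compound 3 (1.19 log units; beyond the scatter)) would lower the number in the same way with the group of compound 4 in place. Also open, from the compounds shown here alone, is where a phenyl ring or a dimethylamino group at this site would fall relative to these three groups.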